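The source may hold more compounds than are shown below. What is called first, only, known or untested is meant among the compounds shown, and "the series" means these compounds.

Of the compounds shown here, three have been measured in an assay on isolated protein for inhibition of 15-hydroxyprostaglandin dehydrogenase [NAD(+)] (Homo sapiens), read by fluorescence, with a stated time of 15 min; on this read-out higher numbers stand for weaker inhibition and lower numbers for stronger inhibition. Compound 1 `Cc1cc(-c2nnc3n2CCCCCCC3)c(C)n1-c1ccccc1` gives 383 nM. Compound 2 `O=C(c1ccc2c(c1)ncn2-c1ccccc1)N1CCCCC1` gives 22 nM, and compound 3 `COc1cccc(-n2cnc3cc(C(=O)N4CCCCC4)ccc32)c1` gives 19 nM. Compound 3 sits close to compound 2, the two being within the scatter of each other, while compound 1 is far away at a much higher number. Compound 4 `CC(C)c1cccc(-n2cnc3cc(C(=O)N4CCCCC4)ccc32)c1` differs from compound 3 by isopropyl in place of methoxy on an aromatic carbon. Among the compounds with values here, the only step that bears on this position is a 1.2-fold lower number from compound 2 to compound 3 (0.06 log units; within the scatter), which shows that changing the group at this place left the number essentially unchanged. On that basis compound 4 is expected to stay near compound 3, with no step beyond the scatter, so the expected step is a 1.2-fold higher number from compound 3 to compound 4 (0.06 log units; within the scatter). Compound 4 is therefore estimated at 22 nM, with a range from 8 nM to 60 nM.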

Compound 4, half-maximal inhibitory concentration: 68 nM
The estimate for compound 4 lay 3.1-fold (0.49 log units) below the measured number; measured number outside the range, above it.
By their numbers in this assay, from the lowest: compounds 3 and 2 (each within the scatter of the next); then compound 4; then compound 1.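

Hydrogen and methoxy on this aromatic carbon had given numbers within the scatter of each other, which made the place look as if it tolerated change, but isopropyl shows otherwise. In this assay this change gives a 3.6-fold higher number from compound 3 to compound 4 (0.55 log units; beyond the scatter) and, measured against hydrogen, a 3.1-fold higher number from compound 2 to compound 4 (0.49 log units; beyond the scatter). The loss is modest, yet it is beyond the scatter on both comparisons, so the place does respond to the group it carries. No measurement here accounts for this difference. As far as these compounds go, whether ethyl, an amine or a longer chain on this carbon would track methoxy or isopropyl remains open.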